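The source may report more compounds than this note shows. Statements on the series, on what has been measured and on what is new or still open speak of the compounds shown alone.

- Compound 1 (`CCCCCCCCCCCC[C@@H](O)[C@H]1CC[C@H]([C@H](O)CCCCCCCCCCNC(=O)c2ccnn2C)O1`): 30900 nM
- Compound 2 (`CCCCCCCCCCCC[C@@H](O)[C@H]1CC[C@H]([C@H](O)CCCCCCCCCCN(C)C(=O)c2ccnn2C)O1`): 6030 nM

These values come from a functional assay on OVCAR-8 cells (Homo sapiens) for inhibition, read by sulforhodamine B assay, with a stated time of 48 h; a higher number here means a weaker inhibitor of growth, a lower number a stronger inhibitor of growth. Of the two measured compounds, compound 2 has the lower number, at 6030 nM.

Compound 3 (`CCCCCCCCCCCC[C@@H](O)[C@H]1CC[C@H]([C@H](O)CCCCCCCCCCNCc2ccnn2C)O1`) has not yet been measured. It differs from compound 2 at one place: ((1-methyl-1H-pyrazol-5-yl)methyl)amino in place of methyl((1-methyl-1H-pyrazol-5-yl)carbonyl)amino on a saturated chain carbon, ten or more bonds along the chain from an oxygen on a saturated carbon and a saturated ring carbon. Here, ((1-methyl-1H-pyrazol-5-yl)methyl)amino stands in place of methyl((1-methyl-1H-pyrazol-5-yl)carbonyl)amino on a saturated chain carbon.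

Among the compounds with values here, only one measured step bears on this change: a 5.1-fold lower number from compound 1 to compound 2 (0.71 log units; beyond the scatter). That step, methyl in place of hydrogen on an amide-type nitrogen, is modest but beyond the scatter. Within the data shown here, it offers only partial guidance, since no measured step shows the loss of the carbonyl. With no direction established, no shift beyond the scatter is expected, although the uncertainty is wide.

The estimated change is a 1.0-fold lower number from compound 2 to compound 3 (0.00 log units; within the scatter).

For compound 3, the expected value is 6000 nM, with an estimated range of 1800 nM to 20000 nM.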

Compound 3, concentration for 50% growth inhibition: 1580 nM
Estimate against measurement, compound 3: 3.8-fold (0.58 log units) above, and the stated range ends above it.
By their numbers in this assay, from the lowest: compound 3; then compound 2; then compound 1.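

In this assay, ((1-methyl-1H-pyrazol-5-yl)methyl)amino in place of methyl((1-methyl-1H-pyrazol-5-yl)carbonyl)amino gives a 3.8-fold lower number from compound 2 to compound 3 (0.58 log units; beyond the scatter), so losing both the carbonyl and the methyl on nitrogen does not leave the number unchanged but moves it further down. Set against the amide that has no methyl on nitrogen, (1-methyl-1H-pyrazol-5-yl)methyl in place of (1-methyl-1H-pyrazol-5-yl)carbonyl gives a 20-fold lower number from compound 1 to compound 3 (1.29 log units; beyond the scatter), the only step among these compounds printed as large, whereas methyl on the amide-type nitrogen gave a 5.1-fold lower number from compound 1 to compound 2 (0.71 log units; beyond the scatter). This far along the chain, then, the number responds to replacing the carbonyl as well as to substitution on the amide nitrogen, but no measurement at hand explains why.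

The compounds shown leave open what a methyl on the amine nitrogen of compound 3 would do, and whether a sulfonamide at this position would track with the amides or with the amine. They also leave open whether the shift from amide to amine would persist on a longer chain carrying the same nitrogen.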